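Chlorine on the pyridine ring: an expected cytotoxicity limit

This account rests on a few compounds, and the source may have more. Where it says the series, first, only, none or still open, it means among the compounds named here.

Measured compounds:
compound 1, `O=C1N(CCCCCCOc2ccc(Br)cc2)CCN1c1ccncc1`, > 25000 nM
compound 2, `Cc1ccc(OCCCCCCN2CCN(c3ccncc3)C2=O)cc1`, > 25000 nM

In a functional assay on cells (Homo sapiens) for cytotoxicity (on this read-out higher numbers stand for lower toxicity in this test and lower numbers for higher toxicity in this test), compound 1 reaches only a limit of the assay, > 25000 nM. Compound 2 likewise sits at a limit in this assay, > 25000 nM. The step that the two limits leave unreadable from compound 1 to compound 2 therefore cannot be read, because of the limit of > 25000 nM in this assay, at which 2 of the 2 values shown sit. This is all the measured evidence there is.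

Compound 3, `O=C1N(CCCCCCOc2ccc(Br)cc2)CCN1c1ccnc(Cl)c1`, differs from compound 1 in one place: chloro in place of hydrogen on an aromatic carbon, so that the pyridin-4-yl group of the shared core becomes a 2-chloropyridin-4-yl group. No measured step bears on this change; the only step shown is unreadable. Compound 3 is therefore expected to remain at the same limit in this assay, with no readable movement, an estimated 25000 nM (range 10000 nM to 60000 nM). The step from compound 1 to compound 3 that this estimate means is a number no higher from compound 1 to compound 3 (the limit leaves the size open).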

Compound 3, half-maximal cytotoxic concentration: > 25000 nM
Compound 3: no number, only a limit; the forecaster's own chance of this, stated with the estimate: 80%; the middle value sits exactly at the limit.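

In this assay compound 3 gives > 25000 nM, a limit of the assay and not a number. No step can be read from compound 1 to compound 3, because the values share one limit: the limit of > 25000 nM in this assay, at which 3 of the 3 values shown sit.

The compounds shown leave open whether any change on the shared core moves the result in this assay at all.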